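The source may hold more compounds than are shown below. What is called first, only, known or untested is meant among the compounds shown, and "the series" means these compounds.

Compound 1 `CCn1c(/C=C2/C(=O)Nc3ccc(C)cc32)nc2ccccc21` sets the shared core of this small series. In a functional assay on HGC cells (Homo sapiens) for cytotoxicity, read by MTT assay, with a stated time of 48 h (a lower number here means a stronger inhibitor, a higher number a weaker inhibitor), compound 1 gives > 50000 nM, which is a limit of the assay rather than a number. That limit is the one noted in the limit of > 50000 nM in this assay, at which 1 of the 2 values shown sits. Compound 2 `Cn1c(/C=C2/C(=O)Nc3ccc([N+](=O)[O-])cc32)nc2ccccc21` carries a nitro group on the core in place of the methyl of compound 1 and a methyl rather than an ethyl on the aromatic nitrogen. In this assay compound 2 gives "not determined" (no result reported), so it stands at no number on the scale shown, and no step between measured compounds can be drawn from it. Compound 3 `CCn1c(/C=C2/C(=O)Nc3ccc([N+](=O)[O-])cc32)nc2ccccc21` remains unmeasured. The change from compound 2 to compound 3 is methyl in place of hydrogen on a saturated chain carbon bound to an aromatic nitrogen; cut one bond further out, it reads methyl to ethyl. Since no step between measured compounds is shown, the size and direction of this step in this assay cannot be read from the measurements, and nothing beyond the scatter can be claimed for it. Compound 1 shares the ethyl group with compound 3 and reaches only a limit in this assay. Compound 3 is therefore expected to give about 30000 nM in this assay, within an estimated range from 5000 nM to 100000 nM, with a fair chance that the result is again only a limit.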

Compound 3, half-maximal inhibitory concentration: > 50000 nM
Compound 3: only a limit was reported (the forecaster's own chance of this, stated with the estimate: 50%); middle value at least 1.6-fold (0.22 log units) away from the limit.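

No new step can be read for compound 3: compared with compound 1, both results are limits of the assay rather than numbers, and compound 2 has no reported result. The compounds shown leave open whether any change to the shared core or the ethyl group would give a measurable value in this assay.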